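Second methyl on the fused core: expectation for compound 4

This account rests on a few compounds, and the source may have more. Where it says the series, first, only, none or still open, it means among the compounds named here.

Measured in a functional assay on A549 cells (Homo sapiens) for antiproliferative activity, read by MTT assay, with a stated time of 48 h; on this read-out lower numbers stand for stronger inhibition and higher numbers for weaker inhibition:
compound 1, `Cc1ccc2[nH]c(-c3cn(-c4ccccc4)nc3-c3ccccc3)nc2c1`, gives 3610 nM
compound 2, `Cc1cc2nc(-c3cn(-c4ccccc4)nc3-c3ccccc3)[nH]c2cc1C`, gives 14500 nM
compound 3, `COc1ccc(-c2nn(-c3ccccc3)cc2-c2nc3cc(C)ccc3[nH]2)cc1`, gives 5070 nM

Compound 3 differs from compound 1 only in the outer ring: methoxy in place of hydrogen on an aromatic carbon. The step that goes with it, a 1.4-fold higher number from compound 1 to compound 3 (0.15 log units; within the scatter), is small, so the numbers for compound 1 and compound 3 are read as alike.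

The change on the fused core is known once. Compound 2 carries methyl in place of hydrogen on an aromatic carbon and the step is a 4.0-fold higher number from compound 1 to compound 2 (0.60 log units; beyond the scatter), a modest loss of potency in this assay.

Compound 4, `COc1ccc(-c2nn(-c3ccccc3)cc2-c2nc3cc(C)c(C)cc3[nH]2)cc1`, is not yet measured. It differs from compound 3 by methyl in place of hydrogen on an aromatic carbon. The description of the place is word for word the same as for the change from compound 1 to compound 2, so this is the same change, now on the core that carries the methoxy group. Going by the values given here, nothing measured here says whether the methoxy group alters the outcome of that change, so the earlier step is the only guide.

For compound 4 the expected step from compound 3 is a 3.6-fold higher number from compound 3 to compound 4 (0.55 log units; beyond the scatter), resting on compound 2, because a 4.0-fold higher number from compound 1 to compound 2 (0.60 log units; beyond the scatter). The estimate for compound 4 in this assay is 18000 nM, expected to fall between 7000 nM and 45000 nM.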

Compound 4, half-maximal inhibitory concentration: 5850 nM
The estimate for compound 4 lay 3.1-fold (0.49 log units) above the measured number; measured number outside the range, below it.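

In this assay, adding the methyl on the fused core gives a 1.2-fold higher number from compound 3 to compound 4 (0.06 log units; within the scatter), so the loss of potency seen on the core without the methoxy group does not carry over at the same size: the same change on two cores in this assay, a 4.0-fold higher number (0.60 log units; beyond the scatter) from compound 1 to compound 2 and a 1.2-fold higher number (0.06 log units; within the scatter) from compound 3 to compound 4, 3.5-fold (0.54 log units) apart, beyond the scatter of two such steps

Read the other way, adding the methoxy group gives a 2.5-fold lower number from compound 2 to compound 4 (0.39 log units; beyond the scatter), while the same change left the number within the scatter on the core with one methyl: the same change on two cores in this assay, a 1.4-fold higher number (0.15 log units; within the scatter) from compound 1 to compound 3 and a 2.5-fold lower number (0.39 log units; beyond the scatter) from compound 2 to compound 4, 3.5-fold (0.54 log units) apart, beyond the scatter of two such steps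

Going by these compounds alone, the two changes therefore do not add up independently across these four compounds, but a single set of four shows only that a step from one core cannot be assumed to hold on the other; it does not show how general this is or what causes it.

On these data alone, it remains open whether an amine or a carboxylic acid in place of the methoxy group would also change the outcome of the added methyl, and whether a longer chain on the fused core would follow compound 2 or compound 4. As far as these compounds go, how these compounds behave in any other cell line also remains open, since all the numbers here come from this assay.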